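Urea aryl exchange on a shared core: from compound 3 to compound 4

This account rests on a few compounds, and the source may have more. Where it says the series, first, only, none or still open, it means among the compounds named here.

Of the compounds shown here, three with a shared core have been measured in an assay on CHO cells for displacement of a labelled ligand from adenosine receptor A3 (Homo sapiens), tested at 1 uM; on this read-out lower numbers stand for less inhibition and higher numbers for more inhibition at the one concentration tested (going by the name of the read-out). Compound 1 `COc1ccc(C(=O)Nc2nn(-c3ccccc3)c(=O)c3ccccc23)cc1` gives 10%, and compound 2 `O=C(Nc1nn(-c2ccccc2)c(=O)c2ccccc12)c1ccco1` gives 8%, so that a number 2 percentage points lower from compound 1 to compound 2 (within the scatter). Compound 3 `COc1ccc(NC(=O)Nc2nn(-c3ccccc3)c(=O)c3ccccc23)c(OC)c1` gives 33%, the highest of the three numbers, beyond the scatter from both compound 1 and compound 2. Compound 4 `Cc1ccc(NC(=O)Nc2nn(-c3ccccc3)c(=O)c3ccccc23)cc1` has not been measured. It differs from compound 3 as follows: 4-methylphenyl in place of 2,4-dimethoxyphenyl on an amide-type nitrogen. For the measured compounds named here, the only measured step, from compound 1 to compound 2, exchanged an aryl group at a different place and stayed within the scatter; no step bears directly on the urea position. Compound 4 is therefore expected to give roughly 25% in this assay, between 5% and 45%, which is an expected a number 8 percentage points lower from compound 3 to compound 4 (within the scatter), a step that may or may not exceed the scatter.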

Compound 4, a percentage reported as inhibition, at one concentration (the size of the read-out at that concentration, not a potency): 45%
The estimate for compound 4 lay 20 percentage points below the measured number; the measured number falls inside the stated range.
By their numbers in this assay, from the lowest: compounds 2 and 1 (each within the scatter of the next); then compound 3; then compound 4.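

In this assay, the urea aryl group proves open to change: 4-methylphenyl in place of 2,4-dimethoxyphenyl on the amide-type nitrogen gives a number 12 percentage points higher from compound 3 to compound 4 (beyond the scatter) and so shows that neither methoxy group is needed for the read-out here. (4-Methylphenyl)amino on the carbonyl carbon gives larger steps, a number 37 percentage points higher from compound 2 to compound 4 (beyond the scatter) and a number 35 percentage points higher from compound 1 to compound 4 (beyond the scatter) in turn.

Going by these compounds, whether a benzyl or cyclohexyl group on that nitrogen would keep this read-out remains open. Nothing measured here explains these steps.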